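This account rests on a few compounds, and the source may have more. Where it says the series, first, only, none or still open, it means among the compounds named here.

Working notes on the series. In a functional assay on a cell-free system (plasma, Oryctolagus cuniculus) for inhibition, with stated times of 5 min, 1 min and 6 min (on this read-out lower numbers stand for stronger inhibition and higher numbers for weaker inhibition), compound 1 `C=CCOn1c(-c2cccc(C#N)c2)nc(C)c1C(=O)OCC` gives 5860 nM and compound 2 `CCOC(=O)COn1c(-c2cccc(C#N)c2)nc(C)c1C(=O)OCC` gives 6800 nM. Ethoxycarbonyl in place of vinyl on the chain gives a 1.2-fold higher number from compound 1 to compound 2 (0.06 log units; within the scatter).

Compound 3 `CCOC(=O)c1c(C)nc(-c2cccc(C#N)c2)n1OCCC(=O)O` gives > 30000 nM in this assay, which is a limit of the assay and not a number. Its position on the numbers shown is therefore known only as a limit.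

Carboxymethyl in place of vinyl gives an at least 5.1-fold higher number from compound 1 to compound 3 (0.70 log units; beyond the scatter), and carboxymethyl in place of ethoxycarbonyl gives an at least 4.4-fold higher number from compound 2 to compound 3 (0.64 log units; beyond the scatter).

Compound 4 `CCOC(=O)c1c(C)nc(-c2cccc(C#N)c2)n1OCc1ccccc1` keeps the shared core of compound 3 and differs in one group: phenyl in place of carboxymethyl on a saturated chain carbon bound to an oxygen on an aromatic ring. This places phenyl where carboxymethyl stood, on a saturated chain carbon bound to an oxygen on an aromatic ring.

Going by the values given here, no measured step carries phenyl, so the estimate rests on the three steps above. Carboxymethyl is the only replacement in these compounds that gives a step beyond the scatter, and its removal is expected to return the number towards those of compound 1 and compound 2 in this assay. The expected change is a modest or larger fall, and the estimate corresponds to an at least 5.0-fold lower number from compound 3 to compound 4 (0.69 log units; beyond the scatter). Compound 4 is expected at 6000 nM, with an estimated range of 2000 nM to 20000 nM.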

Compound 4, half-maximal inhibitory concentration: 5930 nM
Beside the measured number, compound 4's estimate is 1.0-fold (0.01 log units) above it, and the stated range covers the measured number.
By their numbers in this assay, from the lowest: compounds 1, 4 and 2 (each within the scatter of the next). At a limit, above all of these: compound 3.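

Phenyl on a saturated chain carbon bound to an oxygen on an aromatic ring brings in a six-membered aromatic ring of carbon only, and in this assay it gives an at least 5.0-fold lower number from compound 3 to compound 4 (0.70 log units; beyond the scatter), so this position also tolerates a ring and not only the open-chain vinyl and ethoxycarbonyl ends. Against those two ends, phenyl gives a 1.1-fold lower number from compound 2 to compound 4 (0.06 log units; within the scatter) and a 1.0-fold higher number from compound 1 to compound 4 (0.01 log units; within the scatter), which leaves the three ends level in this read-out and carboxymethyl as the only group here set apart from the others. Compound 3 stands at a limit of the assay and not at a number, so the true size of every step from it remains unknown: the limit of > 30000 nM in this assay, at which 1 of the 4 values shown sits.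

With only one carboxylic acid among the compounds shown, it remains open how a carboxylic acid on a longer chain or an amine at this place would read. On these data alone, it is also open whether a substituted phenyl or a saturated ring would move the number beyond the scatter from the level shared by compound 1, compound 2 and compound 4.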